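Diaminopyrazole azo dyes: nitro to carboxy swap

A few compounds are considered here, and "the series" means these few. Any claim that something is new, unique, unknown or untested is made for them only; others in the source may bear on it.

Three compounds of the series are measured in a functional assay on HOS cells (Homo sapiens) for antiproliferative activity; on this read-out lower numbers stand for stronger inhibition and higher numbers for weaker inhibition. Compound 1 `Nc1n[nH]c(N)c1/N=N/c1cccc([N+](=O)[O-])c1` carries a nitro group. In this assay compound 1 reaches only the limit > 100000 nM. Compound 2 `Nc1n[nH]c(N)c1/N=N/c1ccc([N+](=O)[O-])cc1` has the same atoms as compound 1, joined differently; the difference between the two cores is not broken down here. In this assay compound 2 likewise gives only the limit > 100000 nM. Compound 3 `Nc1n[nH]c(N)c1/N=N/c1cccc(C(=O)O)c1` replaces the nitro group of compound 1 by a carboxy group: carboxy in place of nitro on an aromatic carbon. In this assay compound 3 also stops at the limit > 100000 nM. The step that the two limits leave unreadable from compound 1 to compound 3 therefore cannot be read, since (the limit of > 100000 nM in this assay, at which 3 of the 3 values shown sit).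

Compound 4 `Nc1n[nH]c(N)c1/N=N/c1ccc(C(=O)O)cc1`, still to be measured, arises from compound 2 by the same kind of change: carboxy in place of nitro on an aromatic carbon. The place differs from the change on compound 1 in that the group sits para rather than meta to the group of 9 heavy atoms.

For compound 4 a step that the limit leaves unreadable from compound 2 to compound 4 is expected, resting on compound 1 and compound 3 both sitting at the limit of > 100000 nM in this assay, at which 3 of the 3 values shown sit. The expected value for compound 4 in this assay is 200000 nM, most likely again reported only as a limit.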

Compound 4, half-maximal inhibitory concentration: > 100000 nM
Compound 4: a limit, no number (the forecaster's own chance of this, stated with the estimate: 90%); the middle value does not contradict the limit.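

In this assay compound 4 gives > 100000 nM, a limit and not a number. No step can therefore be read from compound 2 to compound 4: the limit of > 100000 nM in this assay, at which 4 of the 4 values shown sit.

The compounds shown leave open whether carboxy in place of nitro on an aromatic carbon changes the result in this assay at all.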